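The source may hold more compounds than are shown below. What is called first, only, known or untested is meant among the compounds shown, and "the series" means these compounds.

Measured compounds:
- compound 1, `Cc1c(Nc2nc(N)c3c(C#N)c(N4CCC[C@H]4C)n(C)c3n2)cnn1C`, in an assay on isolated protein for binding affinity to Leucine-rich repeat serine/threonine-protein kinase 2 (Homo sapiens), read by TR-FRET and LanthaScreen, with a stated time of 2 h (on this read-out higher numbers stand for weaker inhibition and lower numbers for stronger inhibition), compound 1 gives 2 nM
- compound 2, `C[C@H]1CCCN1c1c(C#N)c2c(N)ncnc2n1C`, in this assay compound 2 gives 136 nM

Going by the values given here, compound 1 gives the lowest of the two numbers in this assay, and its only neighbour, compound 2, sits at a clearly higher value, a gap well beyond the scatter. Compound 2 lacks the whole aminopyrazole arm that compound 1 carries on its shared core, so the two values simply show that this arm is where most of the measured strength comes from.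

Compound 3, `Cc1n[nH]cc1Nc1nc(N)c2c(C#N)c(N3CCC[C@H]3C)n(C)c2n1`, is not yet measured. It keeps that arm but alters it: 3-methyl-1H-pyrazol-4-yl in place of 1,5-dimethyl-1H-pyrazol-4-yl on a nitrogen on an aromatic ring. In plain terms one methyl group is removed and a ring hydrogen, a hydrogen-bond donor, appears where it was. Among the compounds with values here, since no pair of measured compounds shows this change, the size of the step can only be guessed. The expectation is a small shift towards a higher number, of the order of the scatter itself, so that the expected step is a 2.0-fold higher number from compound 1 to compound 3 (0.30 log units; within the scatter). Compound 3 is therefore estimated at 4 nM, with a range from 1 nM to 20 nM.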

Compound 3, inhibition constant: 1 nM
Compound 3: the middle estimate sits 4.0-fold (0.60 log units) above what was measured, and the stated range covers the measured number.
By their numbers in this assay, from the lowest: compounds 3 and 1 (each within the scatter of the next); then compound 2.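

In this assay the exchange of 1,5-dimethyl-1H-pyrazol-4-yl for 3-methyl-1H-pyrazol-4-yl on a nitrogen on an aromatic ring gives a 2.0-fold lower number from compound 1 to compound 3 (0.30 log units; within the scatter) and so leaves the two compounds indistinguishable on this read-out. The earlier compounds shown here showed only what happens when the whole arm is absent, whereas this pair shows that the arm can lose one methyl group and gain a hydrogen-bond donor without the reading moving beyond the scatter. Nothing given here explains why the two groups read alike.

Still open, on these data alone, is how a pyrazole carrying no methyl group at all, or an ethyl or cyclopropyl group in place of the methyl, would read. A different ring on that nitrogen, such as a phenyl or a pyridine, is also untested among the compounds shown.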